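Swapping an aryl ether for a hexyl ether on the shared core

The source may hold more compounds than are shown below. What is called first, only, known or untested is meant among the compounds shown, and "the series" means these compounds.

Measured compounds:
- compound 1 `CSc1cccc(CCCCCC(=O)N2CCOC2=O)c1`: 12800 nM
- compound 2 `O=C(CCCCCc1ccc(O)cc1)N1CCOC1=O`: 61 nM
- compound 3 `Cc1cccc(Oc2ccc(C(=O)N3CCOC3=O)cc2)c1`: 5210 nM

All three compounds share a core built around a cyclic carbamate carrying an acyl group, and all were tested in an assay on HEK293 cells for inhibition of N-acylethanolamine-hydrolyzing acid amidase (Rattus norvegicus), read by LC-MS, with a stated time of 30 min; a higher number here means a weaker inhibitor, a lower number a stronger inhibitor. Compound 2, which reaches the core through a flexible chain ending in a phenol, gives 61 nM. Compound 1, also a chain-linked compound but with a different substituent on its ring, gives 12800 nM. Compound 3, in which the acyl group is an aromatic ring bearing an aryl ether, gives 5210 nM in this assay and so stands second highest of the three numbers, closer to compound 1 than to compound 2, and both gaps are larger than the usual scatter.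

The next compound, compound 4 `CCCCCCOc1ccc(C(=O)N2CCOC2=O)cc1`, differs from compound 3 in one place: hexyl in place of 3-methylphenyl on an oxygen on an aromatic ring. Among the measured compounds shown here, no step between two measured compounds tracks exactly this change. The values of compound 2 and compound 1 show that a flexible chain can sit beside a strong or a weak number, so the direction is open. A modest gain is the expectation here, with the step from compound 3 to compound 4 estimated at a 3.5-fold lower number from compound 3 to compound 4 (0.54 log units; beyond the scatter). Compound 4 is therefore expected to give about 1500 nM in this assay, within a range from 300 nM to 8000 nM.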

Compound 4, half-maximal inhibitory concentration: 640 nM
Estimate against measurement, compound 4: 2.3-fold (0.37 log units) above; the range from low to high includes it.
By their numbers in this assay, from the lowest: compound 2; then compound 4; then compound 3; then compound 1.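

In this assay, among the compounds shown here, replacing 3-methylphenyl with hexyl on an oxygen on an aromatic ring gives an 8.1-fold lower number from compound 3 to compound 4 (0.91 log units; beyond the scatter) and so marks this oxygen as a place where the choice of group changes the number, something no earlier pair of compounds could show. The step also shows that the aromatic ring of compound 3 is not needed at this place for inhibition, since compound 4, with an open chain and no ring there, is the stronger inhibitor of the two. Neither group carries a hydrogen-bond donor, a hydrogen-bond acceptor or a net charge, so the swap removes a ring and adds none of these features, yet no measurement here explains why the number falls.

On these data alone, a single pair cannot separate the loss of the ring from the arrival of this particular chain, so it remains open whether the gain belongs to hexyl alone or to open chains in general. A shorter chain such as butyl, a longer chain such as octyl, or a hexyl chain ending in an amine or a carboxylic acid on the same oxygen would each test this further.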